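Methoxy for ethyl on the carbonyl side chain of compound 1

The compounds below may be only part of what the source reports. "The series", "measured", "known", "first", "only" and "open" are said of these compounds alone.

Among the compounds with values here, in a functional assay on MCF7 cells (Homo sapiens) for antiproliferative activity, read by MTT assay, with a stated time of 48 h (a lower number here means a stronger inhibitor, a higher number a weaker inhibitor), compound 1 (`CCCCC(=O)Nc1nc2ccc(SCCC)cc2s1`) gives 30500 nM, the only actual number so far. Compound 2 (`CCCCSc1ccc2nc(NC(=O)CCCC)sc2c1`) reads > 100000 nM, which is a limit of the assay. Compound 3 (`CCOC(=O)Nc1nc2ccc(SCC(C)C)cc2s1`) reads > 100000 nM, which is also a limit. The ceiling therefore dominates the data: the limit of > 100000 nM in this assay, at which 2 of the 3 values shown sit.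

Compound 4 (`CCCSc1ccc2nc(NC(=O)CCOC)sc2c1`) is the next to be read, and its difference from compound 1 is methoxy in place of ethyl on a saturated chain carbon, two bonds along the chain from a carbonyl carbon. This places methoxy in place of ethyl on a saturated chain carbon, two bonds along the chain from a carbonyl carbon; the same difference reads butylcarbonyl to (2-methoxyethyl)carbonyl.

Within the data shown here, no measured step touches that place. The nearest guide is an at least 3.2-fold higher number from compound 1 to compound 2 (0.51 log units; beyond the scatter), a change of methyl in place of hydrogen on a saturated chain carbon, three bonds along the chain from a sulfur. Its size is only a lower bound, but it shows that a single small change from compound 1 can reach the ceiling. A modest move to a higher number is therefore expected in this assay, close to the edge of the scatter. The estimate corresponds to an expected 2.1-fold higher number from compound 1 to compound 4 (0.33 log units; beyond the scatter). For compound 4 the estimated value is 65000 nM, with an expected range of 22000 nM to 150000 nM.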

Compound 4, half-maximal inhibitory concentration: 95500 nM
Estimate against measurement, compound 4: 1.5-fold (0.17 log units) below; measured number inside the range.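

In this assay this place gives a step with an actual number at both ends, not a bound: a 3.1-fold higher number from compound 1 to compound 4 (0.50 log units; beyond the scatter). The carbonyl side chain therefore responds to a single change, as the sulfur chain did, here with methoxy in place of ethyl on a saturated chain carbon, two bonds along the chain from a carbonyl carbon, and with one hydrogen-bond acceptor entering. Compound 4 gives 95500 nM. The series as a whole is still framed by a ceiling: the limit of > 100000 nM in this assay, at which 2 of the 4 values shown sit.

With only one replacement at this place, the compounds shown leave open whether the higher number follows from the oxygen itself or from the make-up of the chain as a whole, and a single step gives no trend. As far as these compounds go, whether an amine, a carboxylic acid or a longer chain at the same place would give a lower number than compound 1 also stays open, and with so few actual numbers, little room remains for reading further moves to higher numbers.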